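Swapping the Amide Arm on Compound 3

A few compounds are considered here, and "the series" means these few. Any claim that something is new, unique, unknown or untested is made for them only; others in the source may bear on it.

Compound 1, `COc1ccc(-c2nc(/N=C(\N)NC(C)C)sc2-c2ccc(OC)cc2)cc1`. In a functional assay with Oryctolagus cuniculus as the target (a higher number here means a weaker inhibitor, a lower number a stronger inhibitor), compound 1 gives only a limit, > 100 nM.
Compound 2, `COc1ccc(-c2nc(/N=C(\N)[N+]3(C)CCCCC3)sc2-c2ccc(OC)cc2)cc1`. In this assay compound 2 also gives only a limit, > 1000 nM.
Compound 3, `COc1ccc(-c2nc(CNC(C)=O)sc2-c2ccc(OC)cc2)cc1`. In this assay compound 3 gives 15 nM.

Compound 3 therefore stands as the only one of the three with a real number; the other two sit at limits, as the limit of > 100 nM in this assay, at which 1 of the 3 values shown sits, and the limit of > 1000 nM in this assay, at which 1 of the 3 values shown sits, show. The two measured steps that reach compound 3 are an at least 6.6-fold lower number from compound 1 to compound 3 (0.82 log units; beyond the scatter) and an at least 66-fold lower number from compound 2 to compound 3 (1.82 log units; beyond the scatter), both read only as lower bounds because they start from limits.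

Compound 4, `CCN(CC)C(=O)c1nc(-c2ccc(OC)cc2)c(-c2ccc(OC)cc2)s1`, carries the change (diethylcarbamoyl in place of acetamidomethyl on an aromatic carbon). Among the compounds with values here, no measured step covers this exact exchange. The two known steps show that the group on this aromatic carbon can move the number strongly, but they all run toward compound 3, not away from it. The entering group keeps the acceptor and drops the hydrogen-bond donor, so compound 4 is expected to lose some potency, with a 4.0-fold higher number from compound 3 to compound 4 (0.60 log units; beyond the scatter) as the expected size. Compound 4 is estimated at 60 nM, between 10 nM and 400 nM.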

Compound 4, half-maximal inhibitory concentration: < 10 nM
Compound 4 gave a limit, no number; the forecaster's own chance of this, stated with the estimate: 20%; middle value at least 6.0-fold (0.77 log units) away from the limit.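

In this assay compound 4 gives only a limit, < 10 nM, which shows that a low number at this aromatic carbon does not require the hydrogen-bond donor of acetamidomethyl. The direct exchange gives an at least 1.5-fold lower number from compound 3 to compound 4 (0.17 log units; that floor lies within the scatter), which leaves compound 3 and compound 4 unranked, but diethylcarbamoyl clearly keeps the potency seen with acetamidomethyl. The other two steps, an at least 10-fold lower number from compound 1 to compound 4 (1.00 log units; beyond the scatter) and an at least 100-fold lower number from compound 2 to compound 4 (2.00 log units; beyond the scatter), show that this second, quite different group also stands well clear of the groups in the two compounds at the weak end.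

As far as these compounds go, how low the true number of compound 4 lies remains open. It is also unknown whether the two ethyl groups matter, which dimethylcarbamoyl, a pyrrolidine amide or a carboxylic acid at the same carbon could test.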